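Adding a Hydroxyl Group to the Alkyne Side Chain

The source may hold more compounds than are shown below. What is called first, only, known or untested is meant among the compounds shown, and "the series" means these compounds.

Of the compounds shown here, three sharing the same core have been measured in a functional assay on 1321-N1 cells for agonist activity at Free fatty acid receptor 1 (Homo sapiens), read by calcium flux, with a stated time of 0.4 s; on this read-out higher numbers stand for larger maximal responses and lower numbers for smaller maximal responses. Compound 1 `O=C(O)CCc1ccc(C#CC2CCCC2)cc1` gives 94% in this assay. Among the compounds with values here, compound 2 `CC(C)=C(C)C#Cc1ccc(CCC(=O)O)cc1` gives 105%, and the single measured step, a number 11 percentage points higher from compound 1 to compound 2 (beyond the scatter), shows a modest rise that lies beyond the scatter. Compound 3 `C/C=C\C#Cc1ccc(CCC(=O)O)c(F)c1` gives 91%, which is the lowest of the three numbers: it sits within the scatter of compound 1 and beyond the scatter of compound 2.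

Compound 4 `C/C(C#Cc1ccc(CCC(=O)O)c(F)c1)=C/CO` has not yet been measured in this assay. It differs from compound 3 in one place: 3-hydroxy-1-methylprop-1-en-1-yl in place of prop-1-en-1-yl on a triple-bonded carbon. Within the data shown here, the only measured step that bears on this change, a number 11 percentage points higher from compound 1 to compound 2 (beyond the scatter), also alters the group on the triple-bonded carbon, and it moved the maximal response only modestly. All three measured compounds reach a response close to the reference, so a large shift in either direction seems unlikely. The expected step is therefore a number 3 percentage points higher from compound 3 to compound 4 (within the scatter), a change that may not rise beyond the scatter. Compound 4 is estimated to give 94%, with a range from 78% to 110%.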

Compound 4, largest response reached (reported as efficacy), in percent of the reference or control that the assay uses: 105%
Beside the measured number, compound 4's estimate is 11 percentage points below it, and the stated range covers the measured number.
By their numbers in this assay, from the lowest: compounds 3 and 1 (each within the scatter of the next); then compounds 2 and 4 (each within the scatter of the next).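

Putting 3-hydroxy-1-methylprop-1-en-1-yl in place of prop-1-en-1-yl on a triple-bonded carbon gives a number 14 percentage points higher from compound 3 to compound 4 (beyond the scatter) in this assay and so produces a modest rise. The earlier step exchanged one all-carbon group for another, whereas this group brings a hydroxyl to the same place, and the maximal response does not fall with it there. Nothing available explains why the response rises with this change.

The new group differs from the old one in both its methyl and its hydroxyl-bearing chain, so the compounds shown cannot divide the step between the two. Also open, as far as these compounds go, is how the response would change with a methoxy group, an amine or a carboxylic acid at the end of that chain in place of the hydroxyl.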